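The source may hold more compounds than are shown below. What is called first, only, known or untested is meant among the compounds shown, and "the series" means these compounds.

Measured so far:
- Compound 1 `C=C1CC[C@@H]2[C@](C)(CO)[C@H](O)CC[C@@]2(C)[C@@H]1CC(Sc1ccc(F)cc1)C1=CCOC1=O`: 16000 nM in a functional assay on PC-3 cells (Homo sapiens) for inhibition, read by MTT assay, with a stated time of 48 h; on this read-out higher numbers stand for weaker inhibition and lower numbers for stronger inhibition
- Compound 2 `C=C1CC[C@@H]2[C@](C)(CO)[C@H](O)CC[C@@]2(C)[C@@H]1CC(Sc1cccs1)C1=CCOC1=O`: 15000 nM in this assay

Within the data shown here, compound 2 holds the lowest of the two numbers in this assay, and the only neighbour is compound 1: a 1.1-fold lower number from compound 1 to compound 2 (0.03 log units; within the scatter).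

Compound 3 `C=C1CC[C@@H]2[C@](C)(CO)[C@H](O)CC[C@@]2(C)[C@@H]1CC(Sc1ccccn1)C1=CCOC1=O` is not yet measured. It differs from compound 2 by pyridin-2-yl in place of thiophen-2-yl on a sulfur. Among the measured compounds shown here, the single measured step that bears on swapping the ring on the sulfur, a 1.1-fold lower number from compound 1 to compound 2 (0.03 log units; within the scatter), stayed within the scatter. The step of no change at the digits printed from compound 2 to compound 3 (within the scatter) is therefore expected to be none beyond the scatter. For compound 3 the estimated value in this assay is 15000 nM, with an expected range from 7000 nM to 32000 nM.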

Compound 3, half-maximal inhibitory concentration: 18000 nM
Compound 3: middle estimate off by 1.2-fold (0.08 log units), on the low side; the range from low to high includes it.
By their numbers in this assay, from the lowest: compounds 2, 1 and 3 (each within the scatter of the next).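

In this assay, the six-membered pyridin-2-yl on the sulfur gives a 1.2-fold higher number from compound 2 to compound 3 (0.08 log units; within the scatter) and a 1.1-fold higher number from compound 1 to compound 3 (0.05 log units; within the scatter), so the result extends beyond the earlier swap between two aromatic rings. Across compounds 1, 2 and 3, neither ring size nor the ring nitrogen in place of sulfur produces a step beyond the scatter. No supporting data explain this flat result.

On these data alone, whether an amine or a carboxylic acid on a saturated chain in place of the aromatic ring would shift the number remains open. Also open, as far as these compounds go, is whether replacing the sulfur with an oxygen would matter.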